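The source may hold more compounds than are shown below. What is called first, only, known or untested is meant among the compounds shown, and "the series" means these compounds.

Compound 1 `COC(=O)c1sc2cc(C#Cc3ccccc3F)cnc2c1N`: > 150000 nM
Compound 2 `COC(=O)c1sc2cc(C#Cc3ccsc3)cnc2c1N`: 29600 nM

Of the compounds shown here, two have been measured in a functional assay on A375-C5 cells (Homo sapiens) for inhibition, read by sulforhodamine B assay, with a stated time of 48 h; a higher number here means a weaker inhibitor of growth, a lower number a stronger inhibitor of growth. Compound 1 gives only a limit there, > 150000 nM, not a number. Among the compounds with values here, compound 2 gives 29600 nM, the only real number so far, so compound 2 stands alone as the one compound with a measured value. Compound 1 sits at the limit (the limit of > 150000 nM in this assay, at which 1 of the 2 values shown sits).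

Within the data shown here, the one measured step is an at least 5.0-fold lower number from compound 1 to compound 2 (0.70 log units; beyond the scatter), which is at least modest and beyond the scatter. Compound 3 `COC(=O)c1sc2cc(C#Cc3ccc(F)cc3)cnc2c1N` now goes the other way: 4-fluorophenyl in place of thiophen-3-yl on a triple-bonded carbon. A fluorinated phenyl ring returns, although the fluorine sits at a different position than in compound 1. As far as these compounds go, the step from compound 1 to compound 2 therefore bears on it directly, but only as a limit, so its true size is unknown. A higher number than compound 2 is expected for compound 3, likely a 3.0-fold higher number from compound 2 to compound 3 (0.48 log units; beyond the scatter), with a fair chance of reaching the limit again. The estimate for compound 3 is 90000 nM, with a range from 30000 nM to 250000 nM.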

Compound 3, concentration for 50% growth inhibition: 48400 nM
The estimate for compound 3 lay 1.9-fold (0.27 log units) above the measured number, within the range that was stated.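

In this assay, thiophen-3-yl is not needed on the triple-bonded carbon for a measurable number to appear: the data show a 1.6-fold higher number from compound 2 to compound 3 (0.21 log units; within the scatter), so 4-fluorophenyl and thiophen-3-yl cannot be told apart here. A fluorine on a phenyl ring therefore does not by itself push the result to the limit, and the change from 2-fluorophenyl to 4-fluorophenyl gives an at least 3.0-fold lower number from compound 1 to compound 3 (0.49 log units; beyond the scatter), which means that in this pair the place of the fluorine on the ring makes a difference beyond the scatter. Compound 1 gives only a limit, not a number, so this step is a minimum size and its true size remains unknown: the limit of > 150000 nM in this assay, at which 1 of the 3 values shown sits.

The compounds shown leave open whether a different group on the triple-bonded carbon, such as a pyridine ring or a phenyl ring carrying an amine or a carboxylic acid, would give a much lower number. They also leave open whether the difference tied to the place of the fluorine is particular to fluorine or would also appear with chlorine or a methoxy group on the phenyl ring.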